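The compounds below may be only part of what the source reports. "The series", "measured", "known", "first", "only" and "open" are said of these compounds alone.

Compound 1 `c1ccc(CNc2[nH]ccc3ncnc2-3)cc1` gives 57% in a functional assay on EL4 cells (Mus musculus) for inhibition, tested at 100 uM; a lower number here means less inhibition, a higher number more inhibition at the concentration tested (going by the name of the read-out).
Compound 2 `[N-]=[N+]=Nc1nccc2c1ncn2[C@H]1C[C@H](O)[C@@H](CO)O1` gives 13% in this assay.
Compound 3 `CCNc1nccc2c1ncn2C1O[C@H](CO)[C@@H](O)[C@H]1O` gives 8% in this assay.

Compound 3 carries the lowest of the three numbers, but the gap to compound 2 lies within the scatter, so the two cannot be set in order; only compound 1 stands beyond the scatter above compound 3. Compound 4 `OCCNc1nccc2c1ncn2C1O[C@H](CO)[C@@H](O)[C@H]1O` differs from compound 3 in one place: hydroxy in place of hydrogen on a saturated chain carbon, two bonds along the chain from a nitrogen on an aromatic ring. Among the measured compounds shown here, no pair of measured compounds shows this change, so the data give no measured step to lean on. Compound 4 is expected to stay close to compound 3, with an estimated step of a number 2 percentage points higher from compound 3 to compound 4 (within the scatter) that does not go beyond the scatter. Compound 4 is estimated to give 10% in this assay, within a range from 0% to 28%.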

Compound 4, a percentage reported as inhibition, at one concentration (the size of the read-out at that concentration, not a potency): 6%
Compound 4: the middle estimate sits 4 percentage points above what was measured, and the stated range covers the measured number.
By their numbers in this assay, from the lowest: compounds 4, 3 and 2 (each within the scatter of the next); then compound 1.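

Ethylamino gives way to (2-hydroxyethyl)amino with a number 2 percentage points lower from compound 3 to compound 4 (within the scatter) in this assay. Among the compounds shown here, this is the first measured step at this position, and it shows that hydroxy in place of hydrogen here does not separate the two compounds. No measurement shown offers an explanation for this result. Still open, as far as these compounds go, is whether an amine or a carboxylic acid in place of the hydroxy, or a longer chain, would move the number beyond the scatter.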